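Sulfonyl to Sulfanyl: Projecting Compound 4

A few compounds are considered here, and "the series" means these few. Any claim that something is new, unique, unknown or untested is made for them only; others in the source may bear on it.

Of the compounds shown here, three of one series have been tested in a functional assay on DU-145 cells (Homo sapiens) for cytotoxicity, read by MTT assay (on this read-out higher numbers stand for weaker inhibition and lower numbers for stronger inhibition), and only compound 2 `CC(O)(CS(=O)(=O)c1ccc(Cl)cc1)c1nc(-c2ccc([N+](=O)[O-])c(C(F)(F)F)c2)no1` gives a number there: 91000 nM. For compound 1 `CC(O)(CS(=O)(=O)c1ccc(Br)cc1)c1nc(-c2ccccc2)no1` the assay reports a limit, > 100000 nM. For compound 3 `CC(O)(CS(=O)(=O)c1ccc(F)cc1)c1nc(-c2ccc(F)c(Cl)c2)no1` the result is likewise a limit, > 100000 nM. Going by the values given here, compound 2 therefore holds the only numerical value among the three, and the other two results sit at the limit of > 100000 nM in this assay, at which 2 of the 3 values shown sit. Among the compounds with values here, no two measured compounds differ in a single place, so no measured step is available to guide a projection.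

Compound 4 `CC(O)(CSc1ccc(Br)cc1)c1nc(-c2ccc([N+](=O)[O-])c(C(F)(F)F)c2)no1` has not yet been measured. It differs from compound 2 in one place: (4-bromophenyl)sulfanyl in place of (4-chlorophenyl)sulfonyl on a saturated chain carbon, two bonds along the chain from an aromatic carbon and an oxygen on a saturated carbon. No measured step touches this part of the molecule, so the size of the change cannot be read from the data shown. With compound 2 standing at 91000 nM and the remaining compounds sitting at the limit of > 100000 nM in this assay, at which 2 of the 3 values shown sit, nothing suggests a large movement. The step of a 1.0-fold lower number from compound 2 to compound 4 (0.00 log units; within the scatter) is expected to lie within the scatter, in either direction. Compound 4 is thus expected to give about 90000 nM, within a range from 30000 nM to 300000 nM, with a real chance that the assay again reports only a limit.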

Compound 4, half-maximal inhibitory concentration: 1600 nM
Compound 4: the middle estimate sits 56-fold (1.75 log units) above what was measured, and the stated range ends above it.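

In this assay, the group on this saturated chain carbon proves to matter a great deal: putting (4-bromophenyl)sulfanyl in place of (4-chlorophenyl)sulfonyl gives a 57-fold lower number from compound 2 to compound 4 (1.75 log units; beyond the scatter). The earlier compounds shown here offered no measured step of any kind, so they could not show that this place in the molecule responds so strongly to a change, or that a compound of this series can give a number far removed from the rest. The other results remain limits and not numbers, which leaves this single step as the only measured comparison in the series: the limit of > 100000 nM in this assay, at which 2 of the 4 values shown sit.

The step combines two changes, sulfonyl to sulfanyl and chlorine to bromine on the aromatic ring, and the compounds shown cannot divide it between them, since neither (4-chlorophenyl)sulfanyl nor (4-bromophenyl)sulfonyl appears on the core of compound 2. Also open, as far as these compounds go, is whether a sulfinyl group or a plain methylene in place of the sulfur would keep the lower number, and whether the same change would act alike with the other aromatic groups of the series.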